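A few compounds are considered here, and "the series" means these few. Any claim that something is new, unique, unknown or untested is made for them only; others in the source may bear on it.

Measured so far in an assay on isolated protein for inhibition of long-chain fatty acid transport protein 1 (Homo sapiens); on this read-out lower numbers stand for stronger inhibition and higher numbers for weaker inhibition:
compound 1 `CCn1c(CNc2ccccc2)nnc1SCC(=O)Nc1ccc(C(=O)OC)cc1`: 540 nM
compound 2 `CCn1c(CNc2ccccc2)nnc1SCc1nc2cc(OC(F)(F)F)ccc2o1`: 100 nM
compound 3 `CCOC(=O)c1ccc(NC(=O)CSc2nnc(CSCc3ccccc3)n2CC)cc1`: 7600 nM

Compound 2 stands lowest of the three in this assay; compound 1 lies higher, beyond the scatter, and compound 3 lies far higher still. Compound 4 `CC/C(=N/O)c1ccc2oc(CSc3nnc(CNc4ccccc4)n3CC)nc2c1` is not yet measured and differs from compound 2 in one place: a group of 5 heavy atoms (3 carbon, 1 nitrogen, 1 oxygen; no ring) in place of a group of 5 heavy atoms (1 carbon, 1 oxygen, 3 fluorine; no ring), on an aromatic carbon. Within the data shown here, no pair of measured compounds carries this change, so there is no step of this kind to lean on. The replacement is expected to shift this assay by a small to moderate step, most likely toward a higher number or none beyond the scatter, so a 2.0-fold higher number from compound 2 to compound 4 (0.30 log units; within the scatter) is the estimate of that step. For compound 4 the expected value is 200 nM, with a range from 60 nM to 700 nM.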

Compound 4, half-maximal inhibitory concentration: 260 nM
Compound 4: the middle estimate sits 1.3-fold (0.11 log units) below what was measured; low and high end bracket the measured number.
By their numbers in this assay, from the lowest: compound 2; then compound 4; then compound 1; then compound 3.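

In this assay the position on the aromatic carbon accepts more than trifluoromethoxy: the hydrogen-bond donor group without a ring, of equal heavy-atom count, gives a 2.6-fold higher number from compound 2 to compound 4 (0.41 log units; beyond the scatter) and so only a modest loss. Among these compounds, this is the first view of a change at this position, and it shows that a hydrogen-bond donor there is compatible with a number in the same range. No measurement on hand explains the step.

From the compounds shown here alone, with a single change, the part played by the donor, the double bond or the chain stays open. Whether a methoxy, an amine or a carboxylic acid at this position would hold the number is also unknown.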